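A chlorophenyl amide after three results at the limit

The source may hold more compounds than are shown below. What is called first, only, known or untested is meant among the compounds shown, and "the series" means these compounds.

In a functional assay on SK-OV-3 cells (Homo sapiens) for antiproliferative activity, read by MTT assay, with a stated time of 72 h (on this read-out higher numbers stand for weaker inhibition and lower numbers for stronger inhibition), three amides sharing one core have so far given no actual numbers. Compound 1 `CCNC(=O)CCc1cccc2c1B(O)OC2` gives > 100000 nM, which is a limit of the assay and not a number. Compound 2 `CC(C)(C)NC(=O)CCc1cccc2c1B(O)OC2` gives > 100000 nM, again a limit. Compound 3 `O=C(CCc1cccc2c1B(O)OC2)Nc1nccs1` gives > 100000 nM, also a limit. Compound 3 therefore stands with the other two at the limit of > 100000 nM in this assay, at which 3 of the 3 values shown sit.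

Compound 4 `O=C(CCc1cccc2c1B(O)OC2)Nc1ccc(Cl)cc1` carries 4-chlorophenyl in place of 1,3-thiazol-2-yl on an amide-type nitrogen, a change counted as 4-chlorophenyl in place of 1,3-thiazol-2-yl on an amide-type nitrogen. The measured steps that bear on this change are a step that the two limits leave unreadable from compound 1 to compound 3, a step that the two limits leave unreadable from compound 2 to compound 3 and a step that the two limits leave unreadable from compound 1 to compound 2. None of them has a size that can be carried over.

Any true number for compound 4 would have to lie on the stronger side of the limit reached by compound 3, so a modest gain is expected, though another limit is quite possible. The expected change is an at least 2.5-fold lower number from compound 3 to compound 4 (0.39 log units; beyond the scatter). The estimated value for compound 4 is 40000 nM, with an expected range from 2000 nM to 100000 nM.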

Compound 4, half-maximal inhibitory concentration: 5000 nM
Compound 4: middle estimate off by 8.0-fold (0.90 log units), on the high side; measured number inside the range.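

In this assay, 4-chlorophenyl on the amide-type nitrogen gives an at least 20-fold lower number from compound 3 to compound 4 (1.30 log units; beyond the scatter), and the same group gives an at least 20-fold lower number from compound 2 to compound 4 (1.30 log units; beyond the scatter) and an at least 20-fold lower number from compound 1 to compound 4 (1.30 log units; beyond the scatter). Within the data shown here, the steps among compounds 1, 2 and 3 cannot be read, so these are the first steps at this position with a readable size, and each is a minimum, as the starting value is a limit. Among the amides shown, only compound 4 gives a true number, while the others remain at the limit: the limit of > 100000 nM in this assay, at which 3 of the 4 values shown sit.

The compounds shown leave open whether the gain comes from the carbon-only aromatic ring or from its chlorine, a question that plain phenyl on the same nitrogen would address. They also leave open how 4-methoxyphenyl or 3-chlorophenyl would compare with 4-chlorophenyl.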